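This account rests on a few compounds, and the source may have more. Where it says the series, first, only, none or still open, it means among the compounds named here.

Of the compounds shown here, two with a shared core have so far been tested in a functional assay on DA-3 cells for cytotoxicity against DA-3 cell line (Mus musculus), read by MTT assay; on this read-out lower numbers stand for stronger inhibition and higher numbers for weaker inhibition. Compound 1 `CC(=O)O[C@@H]1OC(=O)[C@](C)(C(C)=O)[C@@H]1C` gives 7000 nM in this assay, and compound 2 `CC(=O)[C@@]1(C)C(=O)O[C@@H](OC(=O)C(C)(C)C)[C@H]1C` gives 1000 nM. For the measured compounds named here, compound 2 thus has the lower of the two numbers, and its only neighbour is compound 1, separated from it by a step that was beyond the scatter: a 7.0-fold lower number from compound 1 to compound 2 (0.85 log units; beyond the scatter), brought about by tert-butyl in place of methyl on a carbonyl carbon.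

Compound 3 `CC(=O)[C@@]1(C)C(=O)O[C@@H](OC(=O)c2ccccc2)[C@H]1C` differs from compound 2 in a single way: phenyl in place of tert-butyl on a carbonyl carbon. Going by the values given here, the one measured step bears on this change only loosely, since it concerns the same carbonyl carbon but a different pair of groups. Because a 7.0-fold lower number from compound 1 to compound 2 (0.85 log units; beyond the scatter) showed that this place responds to change, some movement is possible, yet the direction cannot be read from one step. The estimate for compound 3 is therefore placed close to compound 2, at 1000 nM with a range of 300 nM to 3500 nM, an expected step of no change at the digits printed from compound 2 to compound 3 (within the scatter).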

Compound 3, half-maximal inhibitory concentration: 1000 nM
The estimate for compound 3 equals the measured number at the digits printed; low and high end bracket the measured number.
By their numbers in this assay, from the lowest: compounds 2 and 3 (each within the scatter of the next); then compound 1.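

In this assay, phenyl in place of tert-butyl on this carbonyl carbon gives no change at the digits printed from compound 2 to compound 3 (within the scatter) and so leaves the reading in place, even though a branched group without a ring has given way to a six-membered aromatic ring. Phenyl in place of methyl gives a 7.0-fold lower number from compound 1 to compound 3 (0.85 log units; beyond the scatter) in the same series, which shows that the earlier gain is not tied to tert-butyl alone: among these three compounds, both groups that replace methyl read lower than methyl itself. Nothing available explains why tert-butyl and phenyl read alike here.

Still open, as far as these compounds go, is how this carbonyl carbon would respond to a longer chain such as n-hexyl, or to a group carrying an amine or a carboxylic acid. From the compounds shown here alone, whether a chlorine or methoxy group on the phenyl ring would shift the number also remains unknown.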